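A few compounds are considered here, and "the series" means these few. Any claim that something is new, unique, unknown or untested is made for them only; others in the source may bear on it.

Compound 1 `CCc1nc(Cc2c[nH]cn2)c(CC)s1`: 1.8 mg/kg
Compound 2 `CCc1nc(Cc2c[nH]cn2)c(C)s1`: > 30 mg/kg (a limit)

Among the measured compounds shown here, in a functional assay on the whole organism (Abdomen) with Mus musculus as the target (a lower number here means that less compound is needed, a higher number that more compound is needed for the effect), compound 1, at 1.8 mg/kg, holds the only actual number so far. The result for compound 2 is the limit of > 30 mg/kg in this assay, at which 1 of the 2 values shown sits.

Next is compound 3 `CCc1sc(-c2ccccc2)nc1Cc1c[nH]cn1`: phenyl in place of ethyl on an aromatic carbon. This is phenyl in place of ethyl on an aromatic carbon, next to the ring nitrogen and next to the ring sulfur.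

For the measured compounds named here, the one measured step, an at least 16-fold higher number from compound 1 to compound 2 (1.22 log units; beyond the scatter), shortens the other ethyl group. It is large, but it bears on this change only indirectly, showing that a small edit to the shared core can cost much in this assay. Going by the values given here, no step at the place now changed has been measured. A moderate move to a higher number is therefore expected, estimated as a 3.3-fold higher number from compound 1 to compound 3 (0.52 log units; beyond the scatter). Compound 3 is estimated at 6 mg/kg, with an expected range of 1.2 mg/kg to 30 mg/kg.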

Compound 3, dose for half-maximal effect: 15 mg/kg
Compound 3: the middle estimate sits 2.5-fold (0.40 log units) below what was measured; the measured number falls inside the stated range.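

The position on the aromatic carbon next to the ring nitrogen and next to the ring sulfur now has its first measured step: in this assay there is an 8.3-fold higher number from compound 1 to compound 3 (0.92 log units; beyond the scatter). At this position the phenyl group gives up ground against the ethyl group, yet compound 3 still returns an actual number, so a group of 6 heavy atoms with one six-membered aromatic ring is tolerated here at a modest cost. Compound 2 remains the only limit in the set, with no actual number: the limit of > 30 mg/kg in this assay, at which 1 of the 3 values shown sits.

With only ethyl and phenyl at this position, the compounds shown do not separate the effect of group size from that of the aromatic ring. A longer chain such as butyl, or an amine, at this position would test that separation.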